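Sulfonamide aryl substitution in a thiazole series

This account rests on a few compounds, and the source may have more. Where it says the series, first, only, none or still open, it means among the compounds named here.

Measured compounds:
compound 1 `Nc1ccc(S(=O)(=O)Nc2nc(-c3cccc([N+](=O)[O-])c3)cs2)cc1` 40 nM
compound 2 `Cc1ccc(S(=O)(=O)Nc2nc(-c3ccc(Cl)c(Cl)c3)cs2)cc1` 56 nM

In an assay on isolated protein for inhibition of kynurenine 3-monooxygenase (Rattus norvegicus) (a lower number here means a stronger inhibitor, a higher number a weaker inhibitor), compound 1 gives 40 nM and compound 2 gives 56 nM; the two numbers are within the scatter of each other, so no order between them is claimed. Compound 3 `O=[N+]([O-])c1cccc(-c2csc(NS(=O)(=O)c3ccc(Cl)cc3)n2)c1` is not yet measured. It differs from compound 1 by chloro in place of amino on an aromatic carbon. For the measured compounds named here, no measured pair shows this change, so no step of known size guides the expectation; a step within the scatter in either direction is expected. Compound 3 is estimated at 50 nM (range 15 nM to 160 nM), which would mean an expected step of a 1.3-fold higher number from compound 1 to compound 3 (0.10 log units; within the scatter).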

Compound 3, half-maximal inhibitory concentration: 84 nM
The estimate for compound 3 lay 1.7-fold (0.23 log units) below the measured number; the measured number falls inside the stated range.
By their numbers in this assay, from the lowest: compounds 1, 2 and 3 (each within the scatter of the next, the first and the last beyond it).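

In this assay, for the compounds shown here, 4-chlorophenyl in place of 4-aminophenyl gives a 2.1-fold higher number from compound 1 to compound 3 (0.32 log units; beyond the scatter) on the shared core, the first comparison that changes only one place. The amino group at this position is therefore not essential for nanomolar inhibition, and its replacement by chloro carries only a modest cost. Nothing available accounts for the size of this step.

Going by these compounds, whether the step comes from losing amino or from adding chloro remains open. A hydroxyl, methoxy or carboxylic acid at this position would help separate the two, and the same change on the core of compound 2 would test whether the step carries over.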